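The compounds below may be only part of what the source reports. "The series", "measured", "known", "first", "only" and "open" are said of these compounds alone.

Of the compounds shown here, two sharing one core have been measured for how strongly they damage a brain tumour cell line. Compound 1 `COc1cc(-c2cc(/C=C/C(=O)c3ccc(N)cc3)[nH]n2)cc(OC)c1OC` carries a 4-aminophenyl on the carbonyl carbon, and in a functional assay on SNB-19 cells (Homo sapiens) for cytotoxicity, read by sulforhodamine B assay, with a stated time of 48 h, tested at 100 uM (on this read-out higher numbers stand for a weaker effect at the one concentration tested and lower numbers for a stronger effect), compound 1 gives -94%. Compound 2 `COc1cc(-c2cc(/C=C/C(=O)c3ccc(Cl)c(Cl)c3)[nH]n2)cc(OC)c1OC` carries a 3,4-dichlorophenyl in that place, and in this assay compound 2 gives 12%. Compound 2 thus stands at the weaker end of the two numbers, with a number 106 percentage points higher from compound 1 to compound 2 (beyond the scatter).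

Compound 3 `COc1ccc(C(=O)/C=C/c2cc(-c3cc(OC)c(OC)c(OC)c3)n[nH]2)cc1OC` is the next step from compound 2: 3,4-dimethoxyphenyl in place of 3,4-dichlorophenyl on a carbonyl carbon. Within the data shown here, no measured step swaps one ring substituent for another of this kind, so the only guide is that the single measured change on this ring moved the result far beyond the scatter, which shows this position matters greatly. A 3,4-dimethoxyphenyl differs from both the amino and the dichloro groups, so the direction is uncertain, though a return toward stronger activity is expected with wide uncertainty, a number 22 percentage points lower from compound 2 to compound 3 (beyond the scatter). Compound 3 is therefore estimated at -10%, with a range from -80% to 40%.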

Compound 3, a percentage reported as activity, at one concentration (the size of the read-out at that concentration, not a potency): -95%
Beside the measured number, compound 3's estimate is 85 percentage points above it, and the stated range ends above it.
By their numbers in this assay, from the lowest: compounds 3 and 1 (each within the scatter of the next); then compound 2.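

In this assay, the large change seen earlier on the ring attached to the carbonyl carbon reverses when 3,4-dimethoxyphenyl replaces 3,4-dichlorophenyl, giving a number 107 percentage points lower from compound 2 to compound 3 (beyond the scatter), while swapping 4-aminophenyl for 3,4-dimethoxyphenyl leaves the result unchanged within the scatter, with a number 1 percentage points lower from compound 1 to compound 3 (within the scatter). The strong read-out is therefore not tied to 4-aminophenyl: among these three compounds, two different substituted rings give matching results, and 3,4-dichlorophenyl alone stands apart, so the same placing of groups in 3,4-dimethoxyphenyl and 3,4-dichlorophenyl does not by itself decide the outcome. No measurement at hand explains why the dimethoxy and dichloro rings give such different results.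

On these data alone, it remains open whether a single group, as in 4-chlorophenyl or 4-methoxyphenyl, would give a result like that of compound 2 or that of compound 3, and where plain phenyl would fall. A carboxylic acid or a dimethylamino group on this ring could further test whether the 3,4-dichlorophenyl result is an exception among the groups this position tolerates.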